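The source may hold more compounds than are shown below. What is called first, only, known or untested is meant among the compounds shown, and "the series" means these compounds.

Compound 2 `CC1(c2ccc(-c3ccncc3)cc2)CC(S(=O)(=O)c2ccc(F)cc2)=C(c2ccc(/C(N)=N\O)cc2)O1` gives 6750 nM in an ADME assay on J774.A1 cells (Mus musculus) for cytotoxicity, read by MTT assay, with a stated time of 72 h (on this read-out lower numbers stand for higher toxicity in this test and higher numbers for lower toxicity in this test), the lower of the two numbers, beneath compound 1 `CC1(c2ccc(Cl)cc2)CC(S(=O)(=O)c2ccc(F)cc2)=C(c2ccc(/C(N)=N\O)cc2)O1` with 31500 nM. Within the data shown here, the one measured step, a 4.7-fold lower number from compound 1 to compound 2 (0.67 log units; beyond the scatter), touches the same aromatic carbon that now changes again. Compound 3 `COc1cc(-c2ccc(C3(C)CC(S(=O)(=O)c4ccc(F)cc4)=C(c4ccc(/C(N)=N\O)cc4)O3)cc2)cc(OC)c1OC` carries 3,4,5-trimethoxyphenyl in place of pyridin-4-yl on an aromatic carbon. Among the measured compounds shown here, no measured step shows this exact replacement, so the direction is open; a change of the same order as that step is thought possible. Compound 3 is expected to give about 8000 nM in this assay, between 2500 nM and 30000 nM, which would be a 1.2-fold higher number from compound 2 to compound 3 (0.07 log units; within the scatter).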

Compound 3, half-maximal cytotoxic concentration: 5220 nM
Compound 3: the middle estimate sits 1.5-fold (0.19 log units) above what was measured; the measured number falls inside the stated range.
By their numbers in this assay, from the lowest: compounds 3 and 2 (each within the scatter of the next); then compound 1.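

In this assay, the change to 3,4,5-trimethoxyphenyl, which has more heavy atoms than pyridin-4-yl, gives a 1.3-fold lower number from compound 2 to compound 3 (0.11 log units; within the scatter), so these two aromatic groups are not separated at this position. The other new step, a 6.0-fold lower number from compound 1 to compound 3 (0.78 log units; beyond the scatter), shows that the drop seen on leaving chloro also occurs with an aromatic ring of carbon only, not just with one holding a nitrogen. Nothing available explains this result.

On these data alone, it remains open whether an amine or a carboxylic acid on this aromatic carbon would give a number nearer that of the chloro compound or those of the two aryl compounds.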